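Replacing an Acetyl with a Methyl on a Ring Amine

The compounds below may be only part of what the source reports. "The series", "measured", "known", "first", "only" and "open" are said of these compounds alone.

Three compounds have been measured so far:
- compound 1, `CC(=O)N1CCN(c2ccc(Nc3ncc(Cl)c(Nc4ccccc4-c4ncn(C(C)C)n4)n3)cc2)CC1`, with 12.5 mL/min/kg
- compound 2, `CC(=O)N1CCc2ccc(Nc3ncc(Cl)c(Nc4ccccc4S(=O)(=O)N(C)C)n3)cc2C1`, with 52.5 mL/min/kg
- compound 3, `CN1CCC(Oc2ccc(Nc3ncc(Cl)c(Nc4ccccc4-c4nnn(C)n4)n3)cc2)CC1`, with 48.3 mL/min/kg

These numbers come from an ADME assay (Rattus norvegicus) for metabolic stability; a lower number here means slower removal, a higher number faster removal of the compound. Compound 2 stands apart from compound 1, whose number is lower by a margin beyond the usual scatter. Compound 3 lies so close to compound 2 that the two cannot be told apart by this assay. Among the compounds with values here, no pair of these three compounds differs in only one place, so no single structural step can be read from the measured set.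

The step to be followed leads from compound 2 to compound 4, `CN1CCc2ccc(Nc3ncc(Cl)c(Nc4ccccc4S(=O)(=O)N(C)C)n3)cc2C1`, which has not yet been measured in this assay. The change is counted as methyl in place of acetyl on an amine nitrogen in a ring.

Within the data shown here, with no matching step among the measured compounds, there is nothing to lean on for the size of this step. Compound 4 is therefore expected to stay near compound 2, with an expected step of a 1.1-fold higher number from compound 2 to compound 4 (0.06 log units; within the scatter) that may well fall inside the scatter. The estimate for compound 4 is 60 mL/min/kg, within a range from 30 mL/min/kg to 120 mL/min/kg.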

Compound 4, clearance: 52.4 mL/min/kg
Beside the measured number, compound 4's estimate is 1.1-fold (0.06 log units) above it; the range from low to high includes it.
By their numbers in this assay, from the lowest: compound 1; then compounds 3, 4 and 2 (each within the scatter of the next).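

Within the data shown here, the step, a 1.0-fold lower number from compound 2 to compound 4 (0.00 log units; within the scatter), is the first single change that can be read directly in this assay, and it lies within the scatter. At this amine nitrogen in a ring, in a six-membered non-aromatic ring that is part of a fused or bridged system of two rings, this read-out cannot tell an acetyl from a methyl, even though the acetyl's 3 heavy atoms and 1 hydrogen-bond acceptor give way to a methyl with 1 heavy atom and no acceptor. No measured evidence here bears on this result.

This one step says nothing about other groups on the same nitrogen, such as a bare hydrogen, an ethyl, a longer chain or a chain ending in a carboxylic acid, any of which could give a different number. It also leaves open whether methyl in place of acetyl would give a similarly small step on the core of compound 1, which carries an acetyl on a different ring amine.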